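Three Compounds at the Assay Limit, a Fourth Expected There

This account rests on a few compounds, and the source may have more. Where it says the series, first, only, none or still open, it means among the compounds named here.

compound 1 `CN1CCN(CCNCc2cn(-c3ccc(F)cc3F)nc2-c2ccc(S(=O)(=O)N(C)C)cc2)CC1` — in an ADME assay on Huh-7 cells (Homo sapiens) for cytotoxicity (on this read-out higher numbers stand for lower toxicity in this test and lower numbers for higher toxicity in this test), compound 1 gives > 20000 nM, a limit of the assay.
compound 2 `COc1ccc(-c2nn(-c3ccc(F)cc3F)cc2CNCCN2CCN(C)CC2)cc1` — in this assay compound 2 gives > 20000 nM, a limit of the assay.
compound 3 `COC(=O)c1ccc(-c2nn(-c3ccc(F)cc3F)cc2CNCCN2CCN(C)CC2)cc1` — in this assay compound 3 gives > 20000 nM, a limit of the assay.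

Compound 3 stands only at a limit in this assay, and the other two values shown are limits as well: the limit of > 20000 nM in this assay, at which 3 of the 3 values shown sit. The steps leading to compound 3 are therefore unreadable, a step that the two limits leave unreadable from compound 1 to compound 3 and a step that the two limits leave unreadable from compound 2 to compound 3, and the remaining step that the two limits leave unreadable from compound 1 to compound 2 is no more readable.

Compound 4 `CN1CCN(CCNCc2cn(-c3ccc(F)cc3F)nc2-c2ccccc2Cl)CC1` differs from compound 3 in one place: 2-chlorophenyl in place of 4-(methoxycarbonyl)phenyl on an aromatic carbon. Going by the values given here, since every measured step among compounds 1, 2 and 3 runs between limits, none of them tells how large a change this aryl swap may bring in this assay; the only guide is that three different groups at this position all left the readout at the limit. Compound 4 is thus expected to sit at that limit as well, an expected step of a number no higher from compound 3 to compound 4 (the limit leaves the size open) that does not read beyond the scatter. The estimate for compound 4 in this assay is 20000 nM, within a range from 10000 nM to 60000 nM.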

Compound 4, half-maximal cytotoxic concentration: > 20000 nM
Compound 4 ended at the assay's limit; the forecaster's own chance of this, stated with the estimate: 85%; the middle value lies on the limit itself.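

Compound 4 sits at the same limit as compound 1, compound 2 and compound 3, so none of the steps to compound 4 can be read in this assay: the limit of > 20000 nM in this assay, at which 4 of the 4 values shown sit.

The compounds shown leave open whether the four groups at this position differ at all in this assay.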